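Replacing a dichlorophenoxy arm with a fluorophenyl sulfide

The source may hold more compounds than are shown below. What is called first, only, known or untested is meant among the compounds shown, and "the series" means these compounds.

compound 1 `Nc1cc(N)c2nc(-c3ccccc3)c(Oc3ccc(Cl)c(Cl)c3)nc2c1`: 43700 nM
compound 3 `COc1ccc(CNc2nc3cc(N)cc(N)c3nc2-c2ccccc2)cc1`: 60300 nM
compound 2 `CCOC(=O)[C@H](CCC(=O)O)NC(=O)c1ccc(Sc2nc3cc(N)cc(N)c3nc2-c2ccccc2)cc1`: < 100000 nM

All three values come from a functional assay on A549 cells (Homo sapiens) for inhibition, read by sulforhodamine B assay, with a stated time of 48 h; on this read-out lower numbers stand for stronger inhibition of growth and higher numbers for weaker inhibition of growth. Compound 1 and compound 3 give numbers that lie within the usual scatter of each other, so neither can be placed ahead of the other. Compound 2 gives only a limit in this assay, (the limit of < 100000 nM in this assay, at which 1 of the 3 values shown sits), not a number.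

Compound 4 `Nc1cc(N)c2nc(-c3ccccc3)c(Sc3ccc(F)cc3)nc2c1` differs from compound 1 by (4-fluorophenyl)sulfanyl in place of 3,4-dichlorophenoxy on an aromatic carbon. Within the data shown here, no two measured compounds differ in a single place, so no measured step shows what this kind of swap does. The estimated step of a 1.1-fold lower number from compound 1 to compound 4 (0.04 log units; within the scatter) is therefore expected to stay within the scatter, with no clear direction. In this assay compound 4 is expected to give about 40000 nM, in a range from 15000 nM to 100000 nM.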

Compound 4, concentration for total growth inhibition: 30900 nM
Beside the measured number, compound 4's estimate is 1.3-fold (0.11 log units) above it; the measured number falls inside the stated range.
By their numbers in this assay, from the lowest: compounds 4, 1 and 3 (each within the scatter of the next).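

In this assay, among these compounds, the step of a 1.4-fold lower number from compound 1 to compound 4 (0.15 log units; within the scatter) is the first comparison between compounds that differ in one place. It shows that (4-fluorophenyl)sulfanyl can take the place of 3,4-dichlorophenoxy on this aromatic carbon with no difference that stands clear of the scatter. Nothing given here accounts for this result.

Going by these compounds, the swap alters the linking atom and the groups on the outer ring together, so their separate contributions remain unknown. On these data alone, how a morpholine or a short alkyl chain would read on this carbon also stays open.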